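Fluoro Added to the Aryl Ring of Compound 1

A few compounds are considered here, and "the series" means these few. Any claim that something is new, unique, unknown or untested is made for them only; others in the source may bear on it.

Compound 1 `Fc1ccc(-c2csc(N/N=C\c3cccs3)n2)cc1` gives 40% in an in vitro assay on BTI-TN-5B1-4 cells for inhibition of Amine oxidase [flavin-containing] A (Homo sapiens), read by Amplex Red, with a stated time of 15 min, tested at 100 uM; on this read-out lower numbers stand for less inhibition and higher numbers for more inhibition at the one concentration tested (going by the name of the read-out). Compound 2 `Fc1ccc(-c2csc(N/N=C\c3ccncc3)n2)cc1` gives 40% in this assay, and the step of no change at the digits printed from compound 1 to compound 2 (within the scatter) lies within the scatter, so compound 1 stands level with compound 2 on the numbers shown. Compound 3 `Fc1ccc(-c2csc(N/N=C\c3cccs3)n2)c(F)c1` differs from compound 1 by fluoro in place of hydrogen on an aromatic carbon. Within the data shown here, the one measured step concerns a different part of the molecule, and no measured step bears on this ring, so no shift beyond the scatter is expected in either direction. Compound 3 is therefore estimated at 40%, between 20% and 60%, an expected step of no change at the digits printed from compound 1 to compound 3 (within the scatter).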

Compound 3, a percentage reported as inhibition, at one concentration (the size of the read-out at that concentration, not a potency): 40%
For compound 3 middle estimate and measured number coincide at the digits printed; the measured number falls inside the stated range.
By their numbers in this assay, from the lowest: compounds 1, 2 and 3 (each within the scatter of the next).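

On the aryl ring, fluoro in place of hydrogen on an aromatic carbon, ortho to a large group and meta to a fluoro group, leaves the read-out in this assay as follows: no change at the digits printed from compound 1 to compound 3 (within the scatter). Among these compounds, this is the first measured step on this ring, since the earlier pair differed only in a different part of the molecule, and the number for compound 3 in this assay stands level with that for compound 1. Nothing available explains this result. Going by these compounds, whether a methoxy group or an amine on this same carbon would move the inhibition remains open.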